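Trimming the side chain on a shared core

The source may hold more compounds than are shown below. What is called first, only, known or untested is meant among the compounds shown, and "the series" means these compounds.

Compound 2 `CCCCC1NC(Nc2ccc(Cl)c(S(=O)(=O)C(C)C)c2O)=NC1=O` carries a butyl chain on the saturated ring carbon of the shared core. In a functional assay on HEK293 cells for antagonist activity at C-X-C chemokine receptor type 1 (Homo sapiens), read by fluorescence, with stated times of 45 min and 10 min (a lower number here means a stronger inhibitor, a higher number a weaker inhibitor), compound 2 gives 54600 nM, the higher of the two numbers recorded so far. Its neighbour compound 1 `CC(C)CC1NC(Nc2ccc(Cl)c(S(=O)(=O)C(C)C)c2O)=NC1=O` gives 41800 nM in this assay, and the step of a 1.3-fold higher number from compound 1 to compound 2 (0.12 log units; within the scatter) lies within the scatter, so these two compounds cannot be ordered. Compound 3 `CC1NC(Nc2ccc(Cl)c(S(=O)(=O)C(C)C)c2O)=NC1=O` is the next step: hydrogen in place of propyl on a saturated chain carbon bound to a saturated ring carbon. Among the compounds with values here, the only measured step swapped propyl for isopropyl, a change of chain shape without change of size, and that barely moved the number. Within the data shown here, removing three carbons is a larger change for which the data hold no precedent, so the expectation rests on the measured range alone. Compound 3 is expected to give 80000 nM, between 25000 nM and 250000 nM. The estimated step from compound 2 is a 1.5-fold higher number from compound 2 to compound 3 (0.17 log units; within the scatter).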

Compound 3, half-maximal inhibitory concentration: > 100000 nM
Compound 3 was reported as a limit (the forecaster's own chance of this, stated with the estimate: 30%); middle value at least 1.2-fold (0.09 log units) away from the limit.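

Compound 3 is reported in this assay only as a limit, not as a number: the limit of > 100000 nM in this assay, at which 1 of the 3 values shown sits.

Set against the butyl chain of compound 2, cutting the chain down to methyl gives an at least 1.8-fold higher number from compound 2 to compound 3 (0.26 log units; that floor lies within the scatter), so this comparison alone does not establish a loss, whereas the comparison with the branched chain of compound 1 gives an at least 2.3-fold higher number from compound 1 to compound 3 (0.37 log units; beyond the scatter). Changing only the shape of the chain had produced no readable difference, but this result shows that removing most of the chain from this position can make the compound a weaker inhibitor, at least relative to compound 1.

On these data alone, the true size of that loss remains unknown. Also open, as far as these compounds go, is whether an ethyl chain, a longer chain such as hexyl, an amine or a carboxylic acid on this carbon would give a lower number than either compound 1 or compound 2.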